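This account rests on a few compounds, and the source may have more. Where it says the series, first, only, none or still open, it means among the compounds named here.

Measured compounds:
- compound 1, `ClCc1cccc(Cn2cnc3nc(Cl)nc(Cl)c32)c1`: 4460 nM
- compound 2, `ClCc1ccc(Cn2cnc3ncnc(Cl)c32)cc1`: "not determined" (no result reported)

Going by the values given here, compound 1 is the only compound here with a number in a functional assay on HCT-116 cells (Homo sapiens) for cytotoxicity, read by sulforhodamine B assay, with a stated time of 48 h (on this read-out higher numbers stand for lower toxicity in this test and lower numbers for higher toxicity in this test), where compound 1 gives 4460 nM. Compound 2 shares the same kind of core but carries one chloro on it, and for compound 2 the assay gave no result, so there is nothing to compare against.

Compound 3, `ClCc1cccc(Cn2cnc3ncnc(Cl)c32)c1`, differs from compound 1 in a single place: hydrogen in place of chloro on an aromatic carbon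

Among the compounds with values here, no step between two measured compounds is known here, so the size of this change in the assay cannot be read from any pair. With only the value of compound 1 as anchor, the expectation is a small step from compound 1 to compound 3, leaning toward weaker cytotoxicity, and possibly none beyond the scatter. Compound 3 is therefore expected to give about 8000 nM, within 2000 nM to 30000 nM, an estimated step of a 1.8-fold higher number from compound 1 to compound 3 (0.25 log units; within the scatter).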

Compound 3, concentration lethal to 50% of the cells: 9540 nM
Estimate against measurement, compound 3: 1.2-fold (0.08 log units) below; the measured number falls inside the stated range.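

In this assay, the chloro on the aromatic carbon between two ring nitrogen atoms has a measurable bearing on the result: putting hydrogen in its place gives a 2.1-fold higher number from compound 1 to compound 3 (0.33 log units; beyond the scatter), a modest step. Since a higher number stands for lower toxicity in this test, the compound with the chloro is the more toxic of this pair, yet that chloro is not needed for a measurable result, as compound 3 gives 9540 nM in this assay. Nothing measured here tells why the number moves.

Going by these compounds, whether an amine or a methoxy group on the same carbon would shift the number further, and in which direction, remains open. Going by these compounds alone, compound 2 has no result, so no step to it can be read.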